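Removing the ring bromine from a rhodanine dienyl ether

This account rests on a few compounds, and the source may have more. Where it says the series, first, only, none or still open, it means among the compounds named here.

Of the compounds shown here, three sharing a rhodanine-derived core have been measured in an assay on isolated protein for inhibition of protein tyrosine phosphatase type IVA 3 (Homo sapiens), tested at 5 ug/mL; on this read-out lower numbers stand for less inhibition and higher numbers for more inhibition at the one concentration tested (going by the name of the read-out). Compound 1, with the structure `O=C1NC(=S)S/C1=C\C=C\c1cc(Br)ccc1OCc1ccccc1Br`, gives 40.3% in this assay. Among the three numbers it stands second highest. Its nearest neighbour is compound 3, the unsubstituted parent `O=C1NC(=S)S/C1=C\C=C\c1ccccc1`, which gives 37.4%, a number that lies within the scatter of the figure for compound 1. Furthest from it is compound 2, with the structure `COc1ccccc1COc1ccccc1/C=C/C=C1\SC(=S)NC1=O`, which gives 78.8%, a number well beyond the scatter above compound 1.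

The next compound to be measured is compound 4, with the structure `O=C1NC(=S)S/C1=C\C=C\c1ccccc1OCc1ccccc1Br`. Its difference from compound 1 is a single one: hydrogen in place of bromo on an aromatic carbon. Among the measured compounds shown here, no measured pair shows this change alone, so the direction must be read from the compounds at hand. Compound 2, which also lacks a bromine on the core ring, gives 78.8%, while compound 1 and compound 3 sit close together.

On this basis the step of a number 9.7 percentage points higher from compound 1 to compound 4 (within the scatter) is expected to be a modest rise, though it could fall within the scatter. Compound 4 is therefore estimated to give 50%, with a range from 25% to 75%.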

Compound 4, a percentage reported as inhibition, at one concentration (the size of the read-out at that concentration, not a potency): 63.1%
Estimate against measurement, compound 4: 13.1 percentage points below; measured number inside the range.
By their numbers in this assay, from the lowest: compounds 3 and 1 (each within the scatter of the next); then compound 4; then compound 2.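

In this assay, among the compounds shown here, the bromo on the aromatic carbon that lies meta to a large group and para to a group of 9 heavy atoms proves to be a real point of change: hydrogen in its place gives a number 22.8 percentage points higher from compound 1 to compound 4 (beyond the scatter) and so provides the first direct reading of this swap. For the compounds shown here, the step is modest but lies beyond the scatter, which the earlier compounds alone could not establish. A second one-place comparison, with bromo in place of methoxy on an aromatic carbon, gives a number 15.7 percentage points lower from compound 2 to compound 4 (beyond the scatter), so the read-out also responds to a change elsewhere in the molecule, although nothing at hand explains either step.

On these data alone, what remains open is whether hydrogen is the best choice at the first carbon, or whether an amine, a carboxylic acid or a short alkyl chain there would raise or lower the number. As far as these compounds go, it also remains open whether the effect of removing the bromo would carry over to compounds with a different group on the other aromatic ring.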